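The compounds below may be only part of what the source reports. "The series", "measured", "known", "first", "only" and "open" are said of these compounds alone.

In a functional assay on HeLa cells (Homo sapiens) for inhibition (on this read-out higher numbers stand for weaker inhibition and lower numbers for stronger inhibition), three compounds sharing one core have been tested. Compound 1 (`O=C(CC(CC(=O)NC1Cc2ccccc2C1)c1ccc(Cl)cc1)NCCN1CCCCC1`) gives 86200 nM, compound 2 (`CCN(C(=O)CC(CC(=O)NCCN1CCCCC1)c1ccc(Cl)cc1)C1Cc2ccccc2C1`) gives 20400 nM and compound 3 (`CCN(CC)CCNC(=O)CC(CC(=O)N(CC)C1Cc2ccccc2C1)c1ccc(Cl)cc1`) gives 24300 nM. Compound 2 sits at the low end of these numbers, level with compound 3 within the scatter, while compound 1 stands apart. Putting ethyl in place of hydrogen on an amide-type nitrogen gave a 4.2-fold lower number from compound 1 to compound 2 (0.63 log units; beyond the scatter). Putting diethylamino in place of piperidin-1-yl gave a 1.2-fold higher number from compound 2 to compound 3 (0.08 log units; within the scatter).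

Compound 4 (`CCN(C(=O)CC(CC(=O)NCCN1CCCCC1)c1ccccc1)C1Cc2ccccc2C1`) is compound 2 with a single change, hydrogen in place of chloro on an aromatic carbon, or 4-chlorophenyl to phenyl: hydrogen in place of chloro on an aromatic carbon. Neither measured step touches this group. All three tested compounds carry the chloro, so what happens without it has not been seen. The two steps offer only a sense of scale, one modest and one within the scatter. A small step in this assay is therefore expected, tilted weakly toward a higher number, and it may not clear the scatter. The estimate for the change is a 1.5-fold higher number from compound 2 to compound 4 (0.17 log units; within the scatter). Compound 4 is expected at 30000 nM, with an estimated range of 12000 nM to 70000 nM.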

Compound 4, half-maximal inhibitory concentration: > 100000 nM
Compound 4: no number, only a limit; the forecaster's own chance of this, stated with the estimate: 10%; middle value at least 3.3-fold (0.52 log units) from the limit.
By their numbers in this assay, from the lowest: compounds 2 and 3 (each within the scatter of the next); then compound 1. At a limit, above all of these: compound 4.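

In this assay compound 4 gives > 100000 nM, which is a limit of the assay and not a number: the limit of > 100000 nM in this assay, at which 1 of the 4 values shown sits. Taking the chloro off the 4-chlorophenyl group, on an aromatic carbon para to a large group, gives an at least 4.9-fold higher number from compound 2 to compound 4 (0.69 log units; beyond the scatter), so this place, which stayed the same across the earlier compounds, clearly counts in this series. Only one heavy atom leaves and everything else in compound 2 stays as it was, so that single chlorine atom separates a measured inhibitor from a compound that reaches the limit.

On these data alone, it remains open whether chloro is specifically needed here or whether another group on the same carbon, such as fluoro, bromo, methyl or methoxy, would serve as well. As far as these compounds go, it is also open whether the same change would have a similar effect on the diethylamino chain of compound 3 or on compound 1, which has the amide hydrogen in place of ethyl, and whether a chloro on another carbon of the aromatic ring would keep the inhibition.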